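The source may hold more compounds than are shown below. What is called first, only, known or untested is meant among the compounds shown, and "the series" means these compounds.

Values in a functional assay on PC-3 cells (Homo sapiens), read by MTT assay, with a stated time of 48 h; a lower number here means a stronger inhibitor, a higher number a weaker inhibitor:
- compound 1 `CCN(CC)CCNC(=O)c1ccc(C(CC)(CC)c2ccc(OCC(O)C(C)(C)C)c(C)c2)n1CC`: 220 nM
- compound 2 `CCn1c(C(=O)NCCN)ccc1C(CC)(CC)c1ccc(OCC(O)C(C)(C)C)c(C)c1`: 940 nM
- compound 3 `C=CCN(C)C(=O)c1ccc(C(CC)(CC)c2ccc(OCC(O)C(C)(C)C)c(C)c2)n1CC`: 25900 nM

Of the three, compound 3 is the weakest, at 25900 nM. Compound 4 `CCn1c(C(=O)N(C)CC(=O)O)ccc1C(CC)(CC)c1ccc(OCC(O)C(C)(C)C)c(C)c1` departs from compound 3 by one change: carboxy in place of vinyl on a saturated chain carbon bound to an amide-type nitrogen. In words, this is carboxy in place of vinyl on a saturated chain carbon bound to an amide-type nitrogen; cut one bond further out, it reads allyl(methyl)amino to (carboxymethyl)(methyl)amino.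

For the measured compounds named here, no measured step covers this exchange directly. The nearest evidence is the pair of large steps on the same carbonyl carbon, a 120-fold higher number from compound 1 to compound 3 (2.07 log units; beyond the scatter) and a 28-fold higher number from compound 2 to compound 3 (1.44 log units; beyond the scatter). These show that the numbers climb steeply when (2-(diethylamino)ethyl)amino or (2-aminoethyl)amino gives way to allyl(methyl)amino. The modest 4.3-fold higher number from compound 1 to compound 2 (0.63 log units; beyond the scatter) shows that the chain end matters less while an amino group remains on it. Compound 4 has no such amino group either, so it is expected to stay with compound 3 at the weak end of this assay. From the compounds shown here alone, no clear direction is expected, and the carboxy group is untested here, so the range is wide. The expected change is small, and the estimated step is a 1.2-fold higher number from compound 3 to compound 4 (0.06 log units; within the scatter). For compound 4 the estimated value is 30000 nM, with an expected range of 8000 nM to 100000 nM.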

Compound 4, half-maximal inhibitory concentration: 23900 nM
Compound 4: middle estimate off by 1.3-fold (0.10 log units), on the high side; the measured number falls inside the stated range.
By their numbers in this assay, from the lowest: compound 1; then compound 2; then compounds 4 and 3 (each within the scatter of the next).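

Working notes on the series: in this assay, carboxy in place of vinyl gives a 1.1-fold lower number from compound 3 to compound 4 (0.03 log units; within the scatter) and so leaves the number on the scatter, even though the exchange adds a hydrogen-bond donor and a hydrogen-bond acceptor at this saturated chain carbon bound to an amide-type nitrogen. The (carboxymethyl)(methyl)amino group also stays far from the amine-ended side chains, with a 25-fold higher number from compound 2 to compound 4 (1.41 log units; beyond the scatter) on exchange for (2-aminoethyl)amino and a 110-fold higher number from compound 1 to compound 4 (2.04 log units; beyond the scatter) on exchange for (2-(diethylamino)ethyl)amino. Among these four compounds, an end group carrying an amine therefore goes with the lower numbers, and none of the four goes against this, while allyl and carboxymethyl are not separated from each other.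

Compound 3 and compound 4 both carry a methyl on the amide nitrogen and lack an amine, so the compounds shown do not separate these two differences from compound 1 and compound 2. A (2-aminoethyl)(methyl)amino group or a (carboxymethyl)amino group on the carbonyl carbon would pull them apart, and a longer chain ending in carboxy would test whether the flat result holds further out. No measurement at hand speaks to the reason for the flat step.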